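Swapping chloro for amino on a weak growth inhibitor

The source may hold more compounds than are shown below. What is called first, only, known or untested is meant among the compounds shown, and "the series" means these compounds.

Measured so far:
compound 1 `Nc1nn(C(=O)Nc2ccc(Cc3ccccc3)cc2)c2ccccc12` — 37700 nM
compound 2 `Nc1nn(C(=O)Nc2ccc(Cc3ccccc3)cc2)c2ccc(Cl)cc12` — 23800 nM

Both compounds were tested in a functional assay on COLO 205 cells (Homo sapiens) for antiproliferative activity, read by sulforhodamine B assay, with a stated time of 48 h; a higher number here means a weaker inhibitor of growth, a lower number a stronger inhibitor of growth. Compound 1 gives 37700 nM. Among the compounds with values here, compound 2 gives 23800 nM, which is the lowest of the two numbers, but the only step known, a 1.6-fold lower number from compound 1 to compound 2 (0.20 log units; within the scatter), is within the scatter, so the two compounds cannot be told apart on these data.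

Compound 3 `Nc1ccc2c(c1)c(N)nn2C(=O)Nc1ccc(Cc2ccccc2)cc1` is not yet measured. It differs from compound 2 by amino in place of chloro on an aromatic carbon. Within the data shown here, the one measured step bears only indirectly on this change: it shows that putting chloro at this position in place of hydrogen moved the number little, a 1.6-fold lower number from compound 1 to compound 2 (0.20 log units; within the scatter). Nothing is known here about an amino group at this position, so the expectation rests on the observation that a change at this spot so far did little.

The estimate is therefore a step of about a 1.3-fold higher number from compound 2 to compound 3 (0.10 log units; within the scatter), that is, no change beyond the scatter in this assay, with a wide range to cover the lack of direct evidence. Compound 3 is expected to give about 30000 nM, between 10000 nM and 90000 nM.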

Compound 3, concentration for total growth inhibition: 26500 nM
Estimate against measurement, compound 3: 1.1-fold (0.05 log units) above, within the range that was stated.
By their numbers in this assay, from the lowest: compounds 2, 3 and 1 (each within the scatter of the next).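

In this assay, within the data shown here, amino brings a hydrogen-bond donor and a hydrogen-bond acceptor to a position where chloro has neither, yet the result is a 1.1-fold higher number from compound 2 to compound 3 (0.05 log units; within the scatter) and so no step that can be told from the scatter. Among these compounds, measured against plain hydrogen, the amino group gives a 1.4-fold lower number from compound 1 to compound 3 (0.15 log units; within the scatter) and that step too stays within the scatter, so a second group now joins chloro in showing no measurable step at this aromatic carbon. Hydrogen, chloro and amino therefore cannot be told apart here, and nothing in the data shown accounts for this.

As far as these compounds go, whether any group at this position can move the number beyond the scatter remains open, and a carboxylic acid, a methoxy group or a longer chain such as aminoethyl would be the next kinds of group to compare. From the compounds shown here alone, all three compounds differ at this one position only, so the effect of changing any other part of the molecule on growth inhibition also remains unknown.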